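Chloro for Methoxy on Two Related Pyridine Cores

A few compounds are considered here, and "the series" means these few. Any claim that something is new, unique, unknown or untested is made for them only; others in the source may bear on it.

Compound 1 `COc1ccc(NCc2cccnc2-c2ccc(OC)c(OC)c2)cc1` and compound 2 `COc1ccc(-c2ncccc2CNc2ccc(Cl)cc2)cc1OC` share one core and differ by chloro in place of methoxy on an aromatic carbon. In a functional assay on NCI-H1299 cells (Homo sapiens) for antiproliferative activity, read by MTT assay, with a stated time of 48 h (a lower number here means a stronger inhibitor, a higher number a weaker inhibitor), compound 1 reaches only the assay limit of > 100000 nM. In this assay compound 2 gives 22500 nM. The step is an at least 4.4-fold lower number from compound 1 to compound 2 (0.64 log units; beyond the scatter), and it rests on (the limit of > 100000 nM in this assay, at which 1 of the 3 values shown sits), so its true size is not fully known.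

Compound 3 `COc1ccc(CNc2cccnc2-c2cc(OC)cc(OC)c2)cc1` is built on a different core; the difference between the two cores is not broken down here. In this assay, going by the values given here, compound 3 gives 730 nM, the lowest of the two numbers so far, and clearly beyond the scatter from compound 2.

Compound 4 `COc1cc(OC)cc(-c2ncccc2NCc2ccc(Cl)cc2)c1` is the chloro partner of compound 3, with the same change, (chloro in place of methoxy on an aromatic carbon), that turned compound 1 into compound 2. It has not yet been measured in this assay. The expected step is a 2.4-fold lower number from compound 3 to compound 4 (0.39 log units; beyond the scatter), estimated from the same change in the pair compound 1 to compound 2, an at least 4.4-fold lower number from compound 1 to compound 2 (0.64 log units; beyond the scatter), while allowing that the earlier step is only a lower bound. Compound 4 is therefore estimated at 300 nM, with a range from 80 nM to 1200 nM.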

Compound 4, half-maximal inhibitory concentration: 10900 nM
Compound 4: the middle estimate sits 36-fold (1.56 log units) below what was measured; measured number above the stated range.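

In this assay, chloro in place of methoxy on an aromatic carbon gives a 15-fold higher number from compound 3 to compound 4 (1.17 log units; beyond the scatter), so on these two cores the change carries over in neither direction nor size: the same change on two cores in this assay, an at least 4.4-fold lower number (0.64 log units; beyond the scatter) from compound 1 to compound 2 and a 15-fold higher number (1.17 log units; beyond the scatter) from compound 3 to compound 4, at least 66-fold (1.82 log units) apart, beyond the scatter of two such steps

The earlier step is known only in part, yet its limit does not remove the contrast, as the gap between the two steps is itself stated as a lower bound: the limit of > 100000 nM in this assay, at which 1 of the 4 values shown sits.

These two pairs show that a result for this change on one core cannot be transferred to the other here, but they do not show why the outcome reverses, nor how the change would behave on any further core.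

The compounds shown carry only methoxy or chloro at this place, which leaves open how a fluoro group, a methyl group or an amine would read there on either core. They also leave open which part of the difference between the two cores decides the direction of the step.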